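The compounds below may be only part of what the source reports. "The series", "measured", "known", "first", "only" and "open" are said of these compounds alone.

Compound 1 has the structure `Clc1ccc(Cn2cc(CSc3nnc(-c4ccccc4)c(-c4ccccc4)n3)nn2)cc1` and in a functional assay on MGC-803 cells (Homo sapiens) for antiproliferative activity, read by MTT assay, with a stated time of 48 h (on this read-out higher numbers stand for weaker inhibition and lower numbers for stronger inhibition), compound 1 gives 13200 nM. Compound 2 has the structure `Brc1ccc(Cn2cc(CSc3nnc(-c4ccccc4)c(-c4ccccc4)n3)nn2)cc1`; in this assay compound 2 reaches only the limit > 100000 nM, which is a limit and not a number. Compound 3 has the structure `Cc1ccc(Cn2cc(CSc3nnc(-c4ccccc4)c(-c4ccccc4)n3)nn2)cc1` and in this assay compound 3 gives 34800 nM.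

Among the two compounds with a number, compound 3 stands at the higher one, with compound 1 as its nearest neighbour at a lower number, the step being a 2.6-fold higher number from compound 1 to compound 3 (0.42 log units; beyond the scatter). Compound 2 sits at the limit (the limit of > 100000 nM in this assay, at which 1 of the 3 values shown sits).

Compound 4 has the structure `Fc1ccc(Cn2cc(CSc3nnc(-c4ccccc4)c(-c4ccccc4)n3)nn2)cc1`. The change from compound 3 is fluoro in place of methyl on an aromatic carbon. The steps already measured all concern this same position: an at least 7.5-fold higher number from compound 1 to compound 2 (0.87 log units; beyond the scatter), a 2.6-fold higher number from compound 1 to compound 3 (0.42 log units; beyond the scatter) and an at least 2.8-fold lower number from compound 2 to compound 3 (0.45 log units; beyond the scatter). Chloro gave the lowest number, methyl a higher one and bromo only a limit, so the position is sensitive, but no fluoro compound has been measured, and the three steps point in no single direction. A step within the scatter is therefore expected, a 1.4-fold lower number from compound 3 to compound 4 (0.14 log units; within the scatter). For compound 4 in this assay the estimate is 25000 nM, with a range from 8000 nM to 80000 nM.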

Compound 4, half-maximal inhibitory concentration: 7590 nM
Compound 4: middle estimate off by 3.3-fold (0.52 log units), on the high side; measured number outside the range, below it.
By their numbers in this assay, from the lowest: compounds 4 and 1 (each within the scatter of the next); then compound 3. At a limit, above all of these: compound 2.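

Fluoro and chloro at this position cannot be told apart in this assay: a 1.7-fold lower number from compound 1 to compound 4 (0.24 log units; within the scatter), so compound 4 and compound 1 count as equal, and the earlier edge of chloro over the other groups is not unique to it. Replacing 4-methylbenzyl with 4-fluorobenzyl gives a 4.6-fold lower number from compound 3 to compound 4 (0.66 log units; beyond the scatter), which shows that exchanging one heavy atom for another here can shift the number beyond the scatter, even though methyl and fluoro match in the counts of donors, acceptors and charge. The halogens therefore do not act as one family, and bromo goes against the shared result of fluoro and chloro, with an at least 13-fold lower number from compound 2 to compound 4 (1.11 log units; beyond the scatter) as the widest step in the set, although compound 2 gives only a limit and not a number, so this step marks a minimum: the limit of > 100000 nM in this assay, at which 1 of the 4 values shown sits.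

What a methoxy group, an amine or a carboxylic acid would do at this position stays open, since the compounds shown carry only halogens and methyl there. Also open, from the compounds shown here alone, is whether the same order of groups would hold on a different core or in other cell lines.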